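Phenyl in Place of Methyl on the Chain

The compounds below may be only part of what the source reports. "The series", "measured", "known", "first", "only" and "open" are said of these compounds alone.

Compound 1 `CC[C@H](CCn1cncn1)c1ccc(Cl)cc1` stands as the lower of the two numbers measured in an ADME assay on HEp-2 cells (Homo sapiens) for cytotoxicity, read by MTT assay, with a stated time of 3 days; a higher number here means that more compound is tolerated, a lower number that less compound is tolerated: in this assay compound 1 gives 50.6 ug/mL, while compound 2 `CC[C@H](CCn1cncn1)c1ccc(OC)cc1` gives 153 ug/mL. Among the measured compounds shown here, the only measured step, a 3.0-fold higher number from compound 1 to compound 2 (0.48 log units; beyond the scatter), concerns an exchange on an aromatic carbon and says nothing about the saturated chain. Compound 3 `Clc1ccc([C@@H](CCn2cncn2)Cc2ccccc2)cc1` differs from compound 1 by phenyl in place of methyl on a saturated chain carbon, two bonds along the chain from an aromatic carbon. For the measured compounds named here, no measured step touches this change, so the data hold nothing that bears directly on it; the one step that exists sits on the aromatic carbon and cannot be carried over to a change on the chain. In the absence of any comparable step, the expected step from compound 1 to compound 3 is a 1.3-fold lower number from compound 1 to compound 3 (0.10 log units; within the scatter), with no direction claimed beyond the scatter and a wide range to reflect that nothing comparable has been measured. Compound 3 is estimated in this assay at 40 ug/mL, with a range from 15 ug/mL to 110 ug/mL.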

Compound 3, half-maximal cytotoxic concentration: 25.9 ug/mL
For compound 3 the middle estimate is 1.5-fold (0.19 log units) above the measured one; the range from low to high includes it.
By their numbers in this assay, from the lowest: compounds 3 and 1 (each within the scatter of the next); then compound 2.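

In this assay, phenyl in place of methyl on a saturated chain carbon, two bonds along the chain from an aromatic carbon, gives a 2.0-fold lower number from compound 1 to compound 3 (0.29 log units; within the scatter). This is the only reading shown for a change at this chain position, and it shows that a single carbon can give way to a six-membered aromatic ring of carbon only without a step that stands clear of the scatter, whereas the one earlier step, on the aromatic carbon, lay beyond it. No measured finding accounts for this reading, so it stands here as an observation without an explanation.

The compounds shown leave open whether other groups on this chain carbon, such as a longer chain like propyl, an amine or a carboxylic acid, would also stay within the scatter of compound 1. They also leave open whether methoxy in place of chloro on the aromatic carbon would give a comparable step with phenyl on the chain; that exchange is shown only with methyl there.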